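Methoxy to hydroxy on the shared core: expected toxicity of compound 4

The source may hold more compounds than are shown below. What is called first, only, known or untested is meant among the compounds shown, and "the series" means these compounds.

Measured compounds:
Compound 1, `COc1cc(-c2nn(-c3cccc(NC(=O)c4ccc(Cl)c(C(F)(F)F)c4)c3)cc2-c2ccncc2)ccc1Cl`, gives a limit in a functional assay on BT-549 cells (Homo sapiens) for inhibition, read by sulforhodamine B assay, with a stated time of 48 h (on this read-out lower numbers stand for higher toxicity in this test and higher numbers for lower toxicity in this test), of > 32500 nM.
Compound 2, `COc1cc(-c2nn(-c3cccc(NC(=O)Nc4cccc(C(F)(F)F)c4)c3)cc2-c2ccncc2)ccc1Cl`, gives 50000 nM in this assay.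
Compound 3, `COc1cc(-c2nn(-c3cccc(NC(=O)Nc4ccc(Cl)c(C(F)(F)F)c4)c3)cc2-c2ccncc2)ccc1Cl`, gives a limit in this assay of > 32500 nM.

Compound 3 stands at a limit rather than at a number, and (the limit of > 32500 nM in this assay, at which 2 of the 3 values shown sit). The steps among the measured compounds are all unreadable: a step that the limit leaves unreadable from compound 1 to compound 2, a step that the two limits leave unreadable from compound 1 to compound 3 and a step that the limit leaves unreadable from compound 2 to compound 3. None of them touches the group changed next.

Compound 4, `O=C(Nc1cccc(-n2cc(-c3ccncc3)c(-c3ccc(Cl)c(O)c3)n2)c1)Nc1ccc(Cl)c(C(F)(F)F)c1`, differs from compound 3 by hydrogen in place of methyl on an oxygen on an aromatic ring. Going by the values given here, no measured step in this assay bears on this change, and the limits leave the size of the other steps unknown. With all three measured values sitting at or near the top of the range, no step beyond the scatter is expected; the value of compound 4 is expected to lie a step that the limit leaves unreadable from compound 3 to compound 4 from compound 3, and most likely to be reported again only as a limit. Compound 4 is therefore estimated at 40000 nM in this assay, within 15000 nM to 100000 nM.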

Compound 4, concentration lethal to 50% of the cells: > 32500 nM
Compound 4: a limit, no number; the forecaster's own chance of this, stated with the estimate: 70%; the middle value does not contradict the limit.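

Compound 3 and compound 4 are both reported only as limits, so the change from methoxy to hydroxy yields no readable step between them, and most of the series stands at the same limit: the limit of > 32500 nM in this assay, at which 3 of the 4 values shown sit. The compounds shown leave open whether this change alters toxicity in this assay, in which direction and by how much.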